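A few compounds are considered here, and "the series" means these few. Any claim that something is new, unique, unknown or untested is made for them only; others in the source may bear on it.

Series notes. Two members of this set have been measured. Compound 1 `Cc1nc(N(C)C(=O)NC(=O)c2c(F)cccc2F)sc1C(=O)N/N=C/c1ccc(C(F)(F)F)cc1` and compound 2 `CN(C(=O)NC(=O)c1c(F)cccc1F)c1nc(C(F)(F)F)c(C(=O)N/N=C/c2cc(C(F)(F)F)cc(C(F)(F)F)c2)s1` were both run in a functional assay on MCF7 cells (Homo sapiens) for inhibition, read by MTT assay, with a stated time of 72 h; a higher number here means a weaker inhibitor, a lower number a stronger inhibitor. In this assay compound 1 gives 30.6 ug/mL. In this assay compound 2 gives 6.85 ug/mL, the lowest of the two numbers on hand; the gap to compound 1 lies beyond the scatter, so compound 2 stands as the stronger inhibitor of the pair.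

Compound 3 `CN(C(=O)NC(=O)c1ccc(F)c(F)c1)c1nc(C(F)(F)F)c(C(=O)N/N=C/c2cc(C(F)(F)F)cc(C(F)(F)F)c2)s1` has not yet been measured. It differs from compound 2 in one place: 3,4-difluorophenyl in place of 2,6-difluorophenyl on a carbonyl carbon. Among the compounds with values here, no measured pair in the set isolates this kind of change, so the size of its effect cannot be read from the data. The working expectation is a small step, if any, most likely within the scatter or a modest weakening.

Compound 3 is expected to give 9.5 ug/mL in this assay, with a range from 3.5 ug/mL to 26 ug/mL. The step this estimate implies, a 1.4-fold higher number from compound 2 to compound 3 (0.14 log units; within the scatter), is expected to be small.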

Compound 3, half-maximal inhibitory concentration: 2.61 ug/mL
The estimate for compound 3 lay 3.6-fold (0.56 log units) above the measured number; the measured number lies below the stated range.
By their numbers in this assay, from the lowest: compound 3; then compound 2; then compound 1.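

In this assay, within the data shown here, 3,4-difluorophenyl in place of 2,6-difluorophenyl on a carbonyl carbon gives a 2.6-fold lower number from compound 2 to compound 3 (0.42 log units; beyond the scatter), the first step that isolates a single change. The two groups have the same atoms and the same counts, so the position responds to where the fluorines sit on the ring, and the 2,6-difluorophenyl group is not required for activity here. No measurement on hand accounts for the size or direction of this step.

Open, going by these compounds, is how far this position tolerates other groups on the carbonyl carbon, such as a plain phenyl, a chlorophenyl or a cyclohexyl. Also open, on these data alone, is whether the same change gives a step of similar size with the other groups of compound 1 in place.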